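The source may report more compounds than this note shows. Statements on the series, on what has been measured and on what is new or still open speak of the compounds shown alone.

In a functional assay on MCF7 cells (Homo sapiens) for cytotoxicity, read by MTT assay, with a stated time of 24 h (on this read-out higher numbers stand for weaker inhibition and lower numbers for stronger inhibition), compound 3 `COc1ccccc1N1CCN(CC(=O)N2CCN(c3nnc(-c4ccc(C)cc4)c(-c4ccc(C)cc4)n3)CC2)CC1` gives 59400 nM. Compound 1 `O=C(CN1CCN(c2cccc(Cl)c2)CC1)N1CCN(c2nnc(-c3ccccc3)c(-c3ccccc3)n2)CC1` gives 56300 nM and compound 2 `O=C(CN1CCN(c2ccc(Cl)cc2)CC1)N1CCN(c2nnc(-c3ccccc3)c(-c3ccccc3)n2)CC1` gives 56300 nM. The number for compound 3 is the highest of the three, but its gaps to compound 1 and to compound 2 are both within the scatter, so the three compounds cannot be separated on these data.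

Compound 4 `Cc1ccc(-c2nnc(N3CCN(C(=O)CN4CCN(c5ccc(Cl)cc5)CC4)CC3)nc2-c2ccc(C)cc2)cc1` differs from compound 3 by 4-chlorophenyl in place of 2-methoxyphenyl on an amine nitrogen in a ring. Among the compounds with values here, the one measured step at this position is no change at the digits printed from compound 1 to compound 2 (within the scatter), a move of the chlorine within the same kind of aryl group that left the read-out unchanged. Within the data shown here, no measured pair exchanges a methoxy-bearing aryl for a chlorine-bearing aryl, so the change from compound 3 to compound 4 has no direct precedent. With all three measured numbers sitting in one narrow band, nothing points to a step beyond the scatter in either direction.

Compound 4 is therefore expected to give 57000 nM in this assay, with a range of 35000 nM to 95000 nM. The expected step of a 1.0-fold lower number from compound 3 to compound 4 (0.02 log units; within the scatter) lies within the scatter.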

Compound 4, half-maximal inhibitory concentration: 660000 nM
Compound 4: middle estimate off by 12-fold (1.06 log units), on the low side; measured number above the stated range.
By their numbers in this assay, from the lowest: compounds 1, 2 and 3 (each within the scatter of the next); then compound 4.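

In this assay, exchanging 2-methoxyphenyl for 4-chlorophenyl on an amine nitrogen in a ring gives an 11-fold higher number from compound 3 to compound 4 (1.05 log units; beyond the scatter), whereas the earlier shift of the chlorine gave no change at the digits printed from compound 1 to compound 2 (within the scatter). This position therefore does respond to the aryl group it carries, and the flat read-out seen so far does not hold for every aryl exchange here. Nothing at hand accounts for the size of this step.

Open, on these data alone, is what an unsubstituted phenyl or a pyridine ring would give at this position, and with it whether the step tracks the departure of the methoxy group or the arrival of the chlorine. Also open, as far as these compounds go, is whether the same exchange has a step of similar size on the core of compound 1.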